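Swapping a Nitrile Aryl for a Fluoroaryl on the Sulfonamide

The source may report more compounds than this note shows. Statements on the series, on what has been measured and on what is new or still open speak of the compounds shown alone.

This account follows a single change made to compound 1, whose structure is `CC(C)CN(c1ccc(C#N)cc1)S(=O)(=O)c1ccc2c(c1)C(O)CC(C1CCOCC1)O2`. In a physicochemical assay for lipophilicity, at pH 7.4 (a lower number here means a more polar compound, a higher number a more lipophilic compound), compound 1 gives 3.07, the lowest of the three numbers measured in this series. The two compounds measured alongside it differ from it in several places at once and share only the sulfonamide bearing an isobutyl chain: compound 2, with structure `CCc1ccc(N(CC(C)C)S(=O)(=O)c2ccc3nc(C4CCOCC4)cc(O)c3c2)cc1`, gives 4.97, and compound 3, with structure `CCc1ccc(N(CC(C)C)S(=O)(=O)c2ccc(OCC3CCOCC3)c3c2CCC3O)cc1`, gives 4.55. Both of those numbers lie well beyond the usual scatter above compound 1, with compound 3 the nearer and compound 2 the further.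

Compound 4, with structure `CC(C)CN(c1ccccc1F)S(=O)(=O)c1ccc2c(c1)C(O)CC(C1CCOCC1)O2`, has not yet been measured. It keeps the whole core of compound 1 and differs only at the sulfonamide nitrogen: 2-fluorophenyl in place of 4-cyanophenyl on a sulfonamide nitrogen.

Within the data shown here, no pair of measured compounds in this set differs in a single place, so no directly measured step exists to lean on. Nonetheless, the change is expected to push the number upward, by a moderate amount clearly beyond the scatter, so that the step of a number 0.63 log units higher from compound 1 to compound 4 (beyond the scatter) is estimated as a rise. Compound 4 is therefore expected to give about 3.7, most likely between 3.3 and 4.2.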

Compound 4, distribution coefficient: 3.39
Compound 4: the middle estimate sits 0.31 log units above what was measured; the range from low to high includes it.
By their numbers in this assay, from the lowest: compound 1; then compound 4; then compound 3; then compound 2.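

Among these compounds, with 2-fluorophenyl in place of 4-cyanophenyl on a sulfonamide nitrogen, this assay gives a number 0.32 log units higher from compound 1 to compound 4 (beyond the scatter) as the first reading of a change made in one place only. The earlier compounds shown here differed in several places at once and could not isolate this position, whereas this modest step, which lies beyond the scatter, shows that the read-out responds to the aryl group on the sulfonamide nitrogen while the core of compound 1 stays the same. No measurement at hand accounts for the rise, so the step stands as an observation without an explanation.

A single step cannot divide the change between the departure of the nitrile and the arrival of the fluorine, and it gives no indication of whether the same exchange would produce a similar step on a different core. The compounds shown also leave open how this assay would respond to a plain phenyl group on this sulfonamide nitrogen, or to a phenyl group carrying an amine or a carboxylic acid.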